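Moving from a Cyclohexyl Amide to a Methoxypiperidine Urea

A few compounds are considered here, and "the series" means these few. Any claim that something is new, unique, unknown or untested is made for them only; others in the source may bear on it.

The study measured three compounds in an assay on HEK293 cells for negative allosteric modulation of metabotropic glutamate receptor 5 (Homo sapiens), read by FLIPR (on this read-out lower numbers stand for stronger inhibition and higher numbers for weaker inhibition), and left a fourth unmeasured. Compound 1 `O=C(c1ccc(Cl)cc1)N1CC(c2nc(-c3cccc(F)c3)no2)C1` is recorded only as a limit in this assay, at > 10000 nM. Compound 2 `CC1CCCC(C(=O)N2CC(c3nc(-c4cccc(Cl)c4)no3)C2)C1` likewise gives only a limit in this assay, > 10000 nM. Among the compounds with values here, compound 3 `Cc1cccc(S(=O)(=O)N2CC(c3nc(-c4cccc(Cl)c4)no3)C2)c1` is the one compound with a number, reading 390 nM in this assay. Compound 2 therefore stands at the limit of > 10000 nM in this assay, at which 2 of the 3 values shown sit, and no numerical comparison between compound 2 and any other compound is possible.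

Compound 4 `COC1CCN(C(=O)N2CC(c3nc(-c4cccc(Cl)c4)no3)C2)CC1` differs from compound 2 in one place: 4-methoxypiperidin-1-yl in place of 3-methylcyclohexyl on a carbonyl carbon. Within the data shown here, no measured step of this kind is available among the three compounds, so the expectation rests only on where compound 2 stands. Compound 4 is expected to remain a weak inhibitor, with the estimated step of an at least 1.2-fold lower number from compound 2 to compound 4 (0.09 log units; that floor lies within the scatter) being no more than modest and of uncertain direction. Compound 4 is estimated to read 8000 nM in this assay, within a range from 2000 nM to 30000 nM.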

Compound 4, half-maximal inhibitory concentration: > 10000 nM
Compound 4: a limit, no number (the forecaster's own chance of this, stated with the estimate: 55%); middle value at least 1.2-fold (0.09 log units) away from the limit.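

Compound 4, like compound 2, is recorded only as a limit, so no step can be read between compound 2 and compound 4: the limit of > 10000 nM in this assay, at which 3 of the 4 values shown sit.

The compounds shown leave open whether 4-methoxypiperidin-1-yl in place of 3-methylcyclohexyl on a carbonyl carbon changes inhibition at all.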